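Working notes: acyl exchange from compound 2 to compound 3

A few compounds are considered here, and "the series" means these few. Any claim that something is new, unique, unknown or untested is made for them only; others in the source may bear on it.

Measured so far:
compound 1 `COc1cc(/C=C/C(=O)c2cccc(N)c2)ccc1O` 50%
compound 2 `COC(=O)C(=O)Nc1cccc(C(=O)/C=C/c2ccc(O)c(OC)c2)c1` 20%

In a functional assay on HUVEC cells (Homo sapiens) for inhibition, tested at 5 ug/mL (on this read-out higher numbers stand for a stronger effect at the one concentration tested and lower numbers for a weaker effect), compound 1 gives 50%, while compound 2 gives 20%. For the measured compounds named here, compound 2 therefore stands lowest of the two numbers, and its nearest neighbour is compound 1; the one measured step, a number 30 percentage points lower from compound 1 to compound 2 (beyond the scatter), goes with (methoxycarbonyl)carbonyl in place of hydrogen on the nitrogen and lies beyond the scatter.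

Compound 3 `COc1cc(/C=C/C(=O)c2cccc(NC(=O)c3ccc(Cl)cc3Cl)c2)ccc1O` is not yet measured. It differs from compound 2 as follows: 2,4-dichlorophenyl in place of methoxycarbonyl on a carbonyl carbon. Going by the values given here, no measured step covers an exchange of one acyl group for another; the step from compound 1 to compound 2 only shows that acylating the nitrogen lowered the number. The expectation for compound 3 therefore rests on little and is wide. A modest rise, a number 15 percentage points higher from compound 2 to compound 3 (beyond the scatter), is expected for compound 3, though not with confidence. The estimate for compound 3 in this assay is 35%, with a range from 5% to 65%.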

Compound 3, a percentage reported as inhibition, at one concentration (the size of the read-out at that concentration, not a potency): 51%
Beside the measured number, compound 3's estimate is 16 percentage points below it; measured number inside the range.
By their numbers in this assay, from the lowest: compound 2; then compounds 1 and 3 (each within the scatter of the next).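

In this assay, the acyl group on the nitrogen matters more than acylation as such: 2,4-dichlorophenyl in place of methoxycarbonyl on the carbonyl carbon gives a number 31 percentage points higher from compound 2 to compound 3 (beyond the scatter) and restores the level of the free amine. The lower number seen for compound 2 therefore does not hold for every acylated nitrogen, and compound 3 goes against that reading, with a number 1 percentage points higher from compound 1 to compound 3 (within the scatter) for (2,4-dichlorophenyl)carbonyl in place of hydrogen on the nitrogen. Nothing at hand bears on the origin of this difference between the two acyl groups.

Open, as far as these compounds go, is whether the result depends on the aromatic ring itself or on its two chlorine atoms, which an unsubstituted phenyl or a 4-chlorophenyl on the same carbonyl would separate. Also open, from the compounds shown here alone, is how a small acetyl group or a free carboxylic acid in place of the methoxycarbonyl would read out here.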